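Working notes: inverting the stereocentre of compound 2

The compounds below may be only part of what the source reports. "The series", "measured", "known", "first", "only" and "open" are said of these compounds alone.

Compound 1 `O=C1c2ccccc2C(=O)N1c1ccccc1-c1ccccc1`: > 100 ug/mL
Compound 2 `C[C@H](C1CCCCC1)N1C(=O)c2c(F)c(F)c(F)c(F)c2C1=O`: > 100 ug/mL

In a functional assay on WI-38 cells (Homo sapiens) for cytotoxicity (a higher number here means a weaker inhibitor, a lower number a stronger inhibitor), compound 2 gives > 100 ug/mL, which is a limit of the assay and not a number. Both measured compounds sit there: the limit of > 100 ug/mL in this assay, at which 2 of the 2 values shown sit. Going by the values given here, neither gives a number, so the series offers no measured step.

Compound 3 `C[C@@H](C1CCCCC1)N1C(=O)c2c(F)c(F)c(F)c(F)c2C1=O` is the next to be read, and the change from compound 2 is this: the two compounds have the same atoms and bonds and differ only in configuration as drawn: 1 of 1 stereo elements differ; a stereocentre at a saturated chain carbon is drawn R in compound 2 and S in compound 3.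

No change beyond the scatter is expected, in either direction, and the expected step is a number no higher from compound 2 to compound 3 (the limit leaves the size open). A reading at the same limit is the likeliest outcome. For compound 3 the estimated value is 100 ug/mL, with an expected range of 50 ug/mL to 200 ug/mL.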

Compound 3, half-maximal inhibitory concentration: > 100 ug/mL
Compound 3: a limit, no number (the forecaster's own chance of this, stated with the estimate: 85%); the middle value lies on the limit itself.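

Compound 2 and compound 3 both read as limits, not numbers, in this assay, so the step between them cannot be read. Going by these compounds, whether the configuration at the stereocentre affects the read-out at all remains open.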